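Aryl variation on the triazole nitrogen in an antiproliferative series

The source may report more compounds than this note shows. Statements on the series, on what has been measured and on what is new or still open speak of the compounds shown alone.

Compound 1, `N#CC1=C(N)Oc2c(N)cc3nc4ccccc4nc3c2C12C(=O)N(Cc1cnnn1-c1ccccc1Br)c1ccccc12`: in a functional assay on A549 cells (Homo sapiens) for antiproliferative activity, read by MTT assay, with a stated time of 48 h (a lower number here means a stronger inhibitor, a higher number a weaker inhibitor), compound 1 gives 27400 nM.
Compound 2, `CCOc1ccc(-n2nncc2CN2C(=O)C3(C(C#N)=C(N)Oc4c(N)cc5nc6ccccc6nc5c43)c3ccccc32)cc1`: in this assay compound 2 gives > 50000 nM, a limit of the assay.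
Compound 3, `CCc1cccc(C)c1-n1nncc1CN1C(=O)C2(C(C#N)=C(N)Oc3c(N)cc4nc5ccccc5nc4c32)c2ccccc21`: in this assay compound 3 gives > 50000 nM, a limit of the assay.

Compound 3 therefore stands only at a limit in this assay; (the limit of > 50000 nM in this assay, at which 2 of the 3 values shown sit). Among the compounds with values here, compound 1 is the single member with a number. The two steps away from it, an at least 1.8-fold higher number from compound 1 to compound 2 (0.26 log units; that floor lies within the scatter) and an at least 1.8-fold higher number from compound 1 to compound 3 (0.26 log units; that floor lies within the scatter), both end at the limit, and a step that the two limits leave unreadable from compound 2 to compound 3. Compound 4, `Cc1ccc(C)c(-n2nncc2CN2C(=O)C3(C(C#N)=C(N)Oc4c(N)cc5nc6ccccc6nc5c43)c3ccccc32)c1`, carries the change (2,5-dimethylphenyl in place of 2-ethyl-6-methylphenyl on an aromatic nitrogen). Both aryl exchanges measured so far reached the limit, so compound 4 is expected to stay near it as well. The estimate for compound 4 in this assay is 50000 nM, within 20000 nM to 120000 nM. The step of a number no higher from compound 3 to compound 4 (the limit leaves the size open) is expected to be small.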

Compound 4, half-maximal inhibitory concentration: > 50000 nM
Compound 4 ended at the assay's limit (the forecaster's own chance of this, stated with the estimate: 60%); the middle value sits exactly at the limit.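

A third aryl group on this aromatic nitrogen now ends at a limit and not at a number: the limit of > 50000 nM in this assay, at which 3 of the 4 values shown sit. In this assay, 2,5-dimethylphenyl in place of 2-bromophenyl gives an at least 1.8-fold higher number from compound 1 to compound 4 (0.26 log units; that floor lies within the scatter), so only a floor is known for this change. The steps among compound 2, compound 3 and compound 4 cannot be read, so these three aryl groups cannot be ranked.

Still open, going by these compounds, is whether 2-chlorophenyl, or a phenyl carrying an amine or a carboxylic acid, on this nitrogen would give a number under the limit.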